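The source may report more compounds than this note shows. Statements on the series, on what has been measured and on what is new or still open speak of the compounds shown alone.

Compound 1 `COc1cc(NC(=O)c2ccc(Cl)c([N+](=O)[O-])c2)ccc1NS(C)(=O)=O`: in an ADME assay on RAW264.7 cells (Mus musculus) for cytotoxicity, read by MTT assay, with a stated time of 48 h (on this read-out lower numbers stand for stronger inhibition and higher numbers for weaker inhibition), compound 1 gives > 250000 nM, a limit of the assay and not a number.
Compound 2 `CS(=O)(=O)Nc1ccc(NC(=O)c2ccc(Cl)cc2)cc1F`: in this assay compound 2 gives 22300 nM.

Compound 2 carries the only number shown; the one further value shown is a limit, so no ranking between the two follows. Compound 3 `CS(=O)(=O)Nc1ccc(NC(=O)c2ccc(Cl)c([N+](=O)[O-])c2)cc1F` differs from compound 2 by nitro in place of hydrogen on an aromatic carbon. Among the compounds with values here, no measured step covers this change; the nearest pointer is the limit of > 250000 nM in this assay, at which 1 of the 2 values shown sits, where the nitro-bearing compound 1 sits. The step from compound 2 to compound 3 is therefore expected to run toward weaker inhibition, a 2.2-fold higher number from compound 2 to compound 3 (0.35 log units; beyond the scatter), modest and possibly not beyond the scatter. Compound 3 is estimated at 50000 nM, within 18000 nM to 200000 nM.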

Compound 3, half-maximal inhibitory concentration: 102000 nM
Beside the measured number, compound 3's estimate is 2.0-fold (0.31 log units) below it; the measured number falls inside the stated range.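

In this assay, the position ortho to the chloro group now has a measured response to nitro in place of hydrogen (a 4.6-fold higher number from compound 2 to compound 3 (0.66 log units; beyond the scatter)). Compound 1 stands at a limit of the assay and not a number (> 250000 nM). Fluoro in place of methoxy on the nitro-bearing compounds also shifts this read-out (an at least 2.4-fold lower number from compound 1 to compound 3 (0.38 log units; beyond the scatter)), so a second place on the shared core matters as well.

Going by these compounds, whether an amine or a carboxylic acid at the nitro position would move the number in the same direction stays open. On these data alone, with methoxy in place of fluoro, the size of the nitro step also stays open.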